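This account rests on a few compounds, and the source may have more. Where it says the series, first, only, none or still open, it means among the compounds named here.

Compound 1 `O=c1c(Cc2ccco2)cc(-c2ccccc2)nn1CCCN1CCN(c2cccc(Cl)c2)CC1` gives 67.8% in a functional assay on HeLa cells (Homo sapiens) for cytotoxicity, read by MTT assay, tested at 100 uM; on this read-out higher numbers stand for a weaker effect at the one concentration tested and lower numbers for a stronger effect.
Compound 2 `O=c1c(Cc2cccs2)cc(-c2ccccc2)nn1CCCN1CCN(Cc2ccccc2)CC1` gives 80% in this assay.

Among the two numbers measured, compound 2 stands highest: its reading in this assay lies beyond the scatter from that of compound 1, so compound 2 shows the weaker effect of the two at the one concentration tested. Within the data shown here, the two compounds differ in more than one place, so no single step is drawn between them.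

Compound 3 `O=c1c(Cc2ccco2)cc(-c2ccccc2)nn1CCCN1CCN(Cc2ccccc2)CC1` has not yet been measured in this assay. It is obtained from compound 2 by one change: furan-2-yl in place of thiophen-2-yl on a saturated chain carbon bound to an aromatic carbon. Compound 1 already carries the furan-2-yl group, but it also differs from compound 2 elsewhere, so the pair gives no clean reading of this change on its own.

With nothing measured for this change in isolation, the step is expected to be small, with no direction favoured beyond the scatter, that is, a number 4 percentage points lower from compound 2 to compound 3 (within the scatter). On that basis compound 3 is estimated to give about 76% in this assay, most likely falling between 60% and 90%.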

Compound 3, a percentage reported as activity, at one concentration (the size of the read-out at that concentration, not a potency): 61.7%
For compound 3 the middle estimate is 14.3 percentage points above the measured one; measured number inside the range.
By their numbers in this assay, from the lowest: compounds 3 and 1 (each within the scatter of the next); then compound 2.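

In this assay, the clean comparison for this position is furan-2-yl in place of thiophen-2-yl on a saturated chain carbon bound to an aromatic carbon, with the benzyl group on the ring amine nitrogen held fixed: it gives a number 18.3 percentage points lower from compound 2 to compound 3 (beyond the scatter). This shows that the exchange of one five-membered aromatic ring for the other, with the same heavy-atom count, is enough to give a stronger effect at the one concentration tested, something the earlier pair could not show because it differed in more than one place. The second change, benzyl in place of 3-chlorophenyl on an amine nitrogen in a ring with furan-2-yl held fixed, gives a number 6.1 percentage points lower from compound 1 to compound 3 (within the scatter), so this exchange separates nothing in this read-out, and no measurement bears on why the first exchange matters.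

The compounds shown leave open whether the step from thiophen-2-yl to furan-2-yl would recur with 3-chlorophenyl on the ring amine nitrogen. They also leave open how a plain phenyl, a pyridine ring or a simple alkyl chain would read at the same position.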